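A few compounds are considered here, and "the series" means these few. Any claim that something is new, unique, unknown or untested is made for them only; others in the source may bear on it.

Compound 1, whose structure is `Cc1nnc(SCc2cc(=O)c3ccccc3o2)s1`, is the starting point of this step. In a functional assay on HeLa cells (Homo sapiens) for cytotoxicity, read by MTT assay, with a stated time of 72 h (a higher number here means a weaker inhibitor, a lower number a stronger inhibitor), compound 1 gives > 25000 nM, which is a limit of the assay rather than a measured number. Two neighbours of compound 1 differ from it in one place each. Compound 2, `Cc1nnc(SCc2cc(=O)c3ccccc3o2)o1`, carries a 5-methyl-1,3,4-oxadiazol-2-yl in place of the 5-methyl-1,3,4-thiadiazol-2-yl on the sulfur; in this assay compound 2 gives > 25000 nM, again only a limit. Compound 3, `Nc1nnc(SCc2cc(=O)c3ccccc3o2)s1`, carries an amino in place of the methyl on an aromatic carbon; in this assay compound 3 gives > 25000 nM, likewise a limit. The steps a step that the two limits leave unreadable from compound 1 to compound 2, a step that the two limits leave unreadable from compound 1 to compound 3 and a step that the two limits leave unreadable from compound 2 to compound 3 therefore cannot be read, since (the limit of > 25000 nM in this assay, at which 3 of the 3 values shown sit).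

Compound 4, `Cc1ccc2oc(CSc3nnc(C)s3)cc(=O)c2c1`, differs from compound 1 by methyl in place of hydrogen on an aromatic carbon. Within the data shown here, no measured step touches this ring, and none of the three measured steps yields a readable size, so nothing beyond the scatter can be expected in this assay in either direction. Compound 4 is accordingly expected to return 30000 nM, within 10000 nM to 100000 nM, most likely again as a limit. The step that the limit leaves unreadable from compound 1 to compound 4 that this estimate implies is expected to be negligible.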

Compound 4, half-maximal inhibitory concentration: > 25000 nM
Compound 4: a limit, no number (the forecaster's own chance of this, stated with the estimate: 80%); the middle value does not contradict the limit.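

Compound 4 and compound 1 both stand only as limits in this assay, so the step between them, methyl in place of hydrogen on an aromatic carbon, cannot be read: the limit of > 25000 nM in this assay, at which 4 of the 4 values shown sit.

The compounds shown leave open whether any change to the shared core gives a measurable value in this assay, and how large any of these steps really is.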